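Chlorophenyl for trifluoromethylphenyl: expectation for compound 4

The source may report more compounds than this note shows. Statements on the series, on what has been measured and on what is new or still open speak of the compounds shown alone.

Working notes on four compounds sharing one core: compound 3 `COc1cc(NC(C)CCCNC(=O)NNC(=O)Nc2cccc(C(F)(F)F)c2)c2ncccc2c1`, compound 2 `COc1cc(NC(C)CCCNC(=O)Nc2cccc(C(F)(F)F)c2)c2ncccc2c1`, compound 1 `COc1cc(NC(C)CCCNC(=O)NNC(=O)Nc2ccc(Cl)cc2)c2ncccc2c1` and the still unmeasured compound 4 `COc1cc(NC(C)CCCNC(=O)Nc2ccc(Cl)cc2)c2ncccc2c1`. In a functional assay on L1210 cells (Mus musculus) for inhibition, read by MTT assay, with a stated time of 72 h (a lower number here means a stronger inhibitor, a higher number a weaker inhibitor), compound 3 gives 4000 nM, compound 2 gives 9200 nM and compound 1 gives 58000 nM. The change 4-chlorophenyl in place of 3-(trifluoromethyl)phenyl on an amide-type nitrogen produced a 15-fold higher number from compound 3 to compound 1 (1.16 log units; beyond the scatter). Separately, the change from compound 1 to compound 2 produced a 6.3-fold lower number from compound 1 to compound 2 (0.80 log units; beyond the scatter). The difference between the cores of compound 2 and compound 3 is not broken down here. Compound 4 carries the same change relative to compound 2, (4-chlorophenyl in place of 3-(trifluoromethyl)phenyl on an amide-type nitrogen), at a place described in identical words. Because compound 3 to compound 1 showed a 15-fold higher number from compound 3 to compound 1 (1.16 log units; beyond the scatter), a weakening of similar direction is expected for compound 4, an 8.7-fold higher number from compound 2 to compound 4 (0.94 log units; beyond the scatter), somewhat damped since the cores differ. Compound 4 is estimated at 80000 nM, expected between 25000 nM and 250000 nM.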

Compound 4, half-maximal inhibitory concentration: 19000 nM
Estimate against measurement, compound 4: 4.2-fold (0.62 log units) above, and the stated range ends above it.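

In this assay, 4-chlorophenyl in place of 3-(trifluoromethyl)phenyl raises the number on both cores, but its size does not carry from one core to the other: the same change on two cores in this assay, a 15-fold higher number (1.16 log units; beyond the scatter) from compound 3 to compound 1 and a 2.1-fold higher number (0.31 log units; beyond the scatter) from compound 2 to compound 4, 7.0-fold (0.85 log units) apart, beyond the scatter of two such steps. The smaller of the two steps is a 2.1-fold higher number from compound 2 to compound 4 (0.31 log units; beyond the scatter). The order of the cores also depends on the aryl group: a 3.1-fold lower number from compound 1 to compound 4 (0.48 log units; beyond the scatter), whereas compound 3 gives 4000 nM and compound 2 gives 9200 nM, so the lower number falls on opposite cores. Two pairs show that the direction held here, but they do not explain the difference in size or show that it extends to other cores.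

Open, from the compounds shown here alone, is how either core behaves with an amine or a carboxylic acid on the phenyl ring. Also open, going by these compounds, is the effect of a longer chain.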